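A few compounds are considered here, and "the series" means these few. Any claim that something is new, unique, unknown or untested is made for them only; others in the source may bear on it.

Measured compounds in a functional assay on MCF7 cells (Homo sapiens) for antiproliferative activity, read by MTT assay, with a stated time of 72 h; a higher number here means a weaker inhibitor, a lower number a stronger inhibitor:
Compound 1, `COc1cc(-c2ncnn2-c2cccc(N)c2)cc(OC)c1OC`: in this assay compound 1 gives > 10000 nM, a limit of the assay and not a number.
Compound 2, `COc1cc(-n2ncnc2-c2ccc(C)cc2)cc(OC)c1OC`: in this assay compound 2 gives 540 nM.
Compound 3, `COc1cc(-c2ncnn2-c2cccc([N+](=O)[O-])c2)cc(OC)c1OC`: in this assay compound 3 gives > 10000 nM, again a limit of the assay.

For the measured compounds named here, compound 2 thus stands as the only compound of the three with an actual number in this assay; the other two values are limits, so it cannot be ordered against them. Going by the values given here, the single measured step, a step that the two limits leave unreadable from compound 1 to compound 3, runs between two limits and its size is unreadable, see (the limit of > 10000 nM in this assay, at which 2 of the 3 values shown sit). It concerns a nitro in place of an amino group on the aryl attached to the core, and bears neither on the position nor on the kind of change considered next.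

Compound 4, `COc1cc(-n2ncnc2-c2ccc(SC)cc2)cc(OC)c1OC`, differs from compound 2 in one place: methylsulfanyl in place of methyl on an aromatic carbon. Among the compounds with values here, no measured pair shows this change, so there is no step to lean on, and the expectation is that the step of no change at the digits printed from compound 2 to compound 4 (within the scatter) stays within the scatter. Compound 4 is therefore estimated at 540 nM in this assay, with a range from 200 nM to 1500 nM.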

Compound 4, half-maximal inhibitory concentration: 390 nM
Estimate against measurement, compound 4: 1.4-fold (0.14 log units) above; the measured number falls inside the stated range.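

In this assay, for the compounds shown here, replacing methyl with methylsulfanyl, read one bond further out as 4-methylphenyl to 4-(methylsulfanyl)phenyl, gives a 1.4-fold lower number from compound 2 to compound 4 (0.14 log units; within the scatter), the first step that can be read as a number. At this place, an aromatic carbon para to a large group, the exchange of one heavy atom for two, with sulfur and one hydrogen-bond acceptor entering, therefore leaves the reading within the scatter, so this one pair gives no sign that the position discriminates between these two groups. Compound 1 and compound 3 remain limits of the assay, the step between them cannot be read, and neither can be compared with this pair, so the two numbered compounds stand apart from the rest of the set: the limit of > 10000 nM in this assay, at which 2 of the 4 values shown sit.

Still open, going by these compounds, is whether this tolerance extends beyond methyl and methylsulfanyl, for instance to an amine, a carboxylic acid or a longer chain such as butyl at the same place. One pair also cannot show whether the same exchange would read alike on another position of the ring or with the shared core arranged differently.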